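Carbamate Exchange Carried From One Core To Another

The source may hold more compounds than are shown below. What is called first, only, known or untested is meant among the compounds shown, and "the series" means these compounds.

Compound 1 `CCCCC(O)Cn1cc(CN2CCC(c3ccccc3)CC2)nn1` and compound 2 `CCCCC(O)Cn1cc(CN2CCN(c3ccccc3)CC2)nn1` differ in their cores, and the difference between the two cores is not broken down here. In an assay on nucleic acid for inhibition of Nucleic Acid, read by fluorescence, tested at 100 uM (a lower number here means less inhibition, a higher number more inhibition at the concentration tested (going by the name of the read-out)), compound 1 gives 16%, the lowest of the three measured numbers, while compound 2 gives 47%. Compound 3 `O=C(NCc1ccccc1)OCC(O)Cn1cc(CN2CCN(c3ccccc3)CC2)nn1` arises from compound 2 by a single change ((benzylcarbamoyl)oxy in place of propyl on a saturated chain carbon, two bonds along the chain from an oxygen on a saturated carbon), and in this assay compound 3 gives 32%, so that a number 15 percentage points lower from compound 2 to compound 3 (beyond the scatter). Compound 4 `O=C(NCc1ccccc1)OCC(O)Cn1cc(CN2CCC(c3ccccc3)CC2)nn1` has not been measured; it relates to compound 1 by the same change at the same place ((benzylcarbamoyl)oxy in place of propyl on a saturated chain carbon, two bonds along the chain from an oxygen on a saturated carbon). A step of a number 13 percentage points lower from compound 1 to compound 4 (beyond the scatter) is expected, resting on that single earlier example because a number 15 percentage points lower from compound 2 to compound 3 (beyond the scatter) on the other core, with no second instance to confirm it. Compound 4 is therefore estimated at about 3% in this assay, between -10% and 18%.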

Compound 4, a percentage reported as inhibition, at one concentration (the size of the read-out at that concentration, not a potency): 29%
The estimate for compound 4 lay 26 percentage points below the measured number; measured number above the stated range.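

On the core of compound 1, the exchange of propyl for (benzylcarbamoyl)oxy gives a number 13 percentage points higher from compound 1 to compound 4 (beyond the scatter) in this assay. Within the data shown here, the same change therefore did not carry from one core to the other, and its direction reversed: the same change on two cores in this assay, a number 15 percentage points lower (beyond the scatter) from compound 2 to compound 3 and a number 13 percentage points higher (beyond the scatter) from compound 1 to compound 4, 28 percentage points apart, beyond the scatter of two such steps With only one pair on each core, this shows that the outcome of the change depended on the core in these compounds, but it does not show why, or what the change would do on any further core. Going by these compounds, it remains open whether a different group at this place, such as an amine, a carboxylic acid or a longer chain, would also reverse between the two cores. On these data alone, whether the reversal is peculiar to (benzylcarbamoyl)oxy also remains open.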